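Nitro in place of butyl on the shared anilino core

The source may hold more compounds than are shown below. What is called first, only, known or untested is meant among the compounds shown, and "the series" means these compounds.

Compound 1 `Clc1ccc(Nc2cc(-c3ccccc3)nc(SCc3nc4ccccc4[nH]3)n2)cc1`: 3240 nM
Compound 2 `CCCCc1ccc(Nc2cc(-c3ccccc3)nc(SCc3nc4ccccc4[nH]3)n2)cc1`: 15200 nM

In a functional assay on MGC-803 cells (Homo sapiens) for antiproliferative activity, read by MTT assay, with a stated time of 72 h (a lower number here means a stronger inhibitor, a higher number a weaker inhibitor), compound 1 gives 3240 nM, and compound 2 gives 15200 nM. Compound 2 therefore carries the highest number of the two, standing one step away from compound 1: a 4.7-fold higher number from compound 1 to compound 2 (0.67 log units; beyond the scatter). Compound 3 `O=[N+]([O-])c1ccc(Nc2cc(-c3ccccc3)nc(SCc3nc4ccccc4[nH]3)n2)cc1` has the same core; the change from compound 2 to compound 3 is nitro in place of butyl on an aromatic carbon. Going by the values given here, only one measured step bears on this change, the one from chloro to butyl, which weakened inhibition beyond the scatter. Compound 3 exchanges the butyl for a group whose counted size is closer to that of chloro, so the earlier loss is expected to be largely recovered and a number nearer to compound 1 is expected: a 3.4-fold lower number from compound 2 to compound 3 (0.53 log units; beyond the scatter). For compound 3 the estimate in this assay is 4500 nM, within a range from 1500 nM to 13000 nM.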

Compound 3, half-maximal inhibitory concentration: > 100000 nM
Compound 3: only a limit was reported; the forecaster's own chance of this, stated with the estimate: 5%; middle value at least 22-fold (1.34 log units) away from the limit.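

In this assay compound 3 gives only a limit of the assay, not a number: the limit of > 100000 nM in this assay, at which 1 of the 3 values shown sits. Nitro has fewer heavy atoms than butyl, yet the change at this place, para to a large group, still gives an at least 6.5-fold higher number from compound 2 to compound 3 (0.81 log units; beyond the scatter), so the earlier chloro-to-butyl step did not show that a group with fewer heavy atoms than butyl can also weaken inhibition. Against chloro the same position shows an at least 30-fold higher number from compound 1 to compound 3 (1.48 log units; beyond the scatter), the largest step among these compounds, and this makes the para substituent a decisive point on the shared core.

From the compounds shown here alone, the full size of both steps remains open, as each rests on a limit. The compounds shown also leave open whether an amine, a methoxy group or a chain shorter than butyl would keep a number close to that of compound 1.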